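The compounds below may be only part of what the source reports. "The series", "measured", "known", "first", "only" and "open" are said of these compounds alone.

Within the data shown here, in a functional assay on MCF-10A cells (Homo sapiens) for antiproliferative activity, with a stated time of 48 h (a lower number here means that less compound is needed, a higher number that more compound is needed for the effect), compound 1 `COc1ccc2nc(C)cc(NCc3ccncc3)c2c1` gives 41600 nM and compound 2 `COc1ccc2nc(C)cc(SCc3ccc(F)cc3)c2c1` gives 50500 nM, so compound 1 stands within the scatter of the only other measured value. Compound 3 `COc1ccc2nc(C)cc(NCc3ccccc3F)c2c1` carries 2-fluorophenyl in place of pyridin-4-yl on a saturated chain carbon bound to a nitrogen on an aromatic ring. Among the measured compounds shown here, no measured pair shows what this exchange does, so no step beyond the scatter is expected in this assay. The expected change is a 1.1-fold lower number from compound 1 to compound 3 (0.04 log units; within the scatter). Compound 3 is estimated at 38000 nM, with an expected range from 16000 nM to 85000 nM.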

Compound 3, half-maximal effective concentration: 17000 nM
Compound 3: middle estimate off by 2.2-fold (0.35 log units), on the high side; the measured number falls inside the stated range.
By their numbers in this assay, from the lowest: compound 3; then compounds 1 and 2 (each within the scatter of the next).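

In this assay, among these compounds, the exchange of pyridin-4-yl for 2-fluorophenyl on a saturated chain carbon bound to a nitrogen on an aromatic ring gives a 2.4-fold lower number from compound 1 to compound 3 (0.39 log units; beyond the scatter) and is the first step beyond the scatter. It shows that the number responds to the group at this place, and that a ring of carbon only is tolerated there. Nothing at hand explains the step. The compounds shown leave open whether the fluorine or the loss of the ring nitrogen carries this step, which plain phenyl at this place would separate. They also leave open how 2-chlorophenyl or 2-methoxyphenyl would compare.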